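From compound 1 to compound 3 in a cytotoxicity assay

The source may report more compounds than this note shows. Statements on the series, on what has been measured and on what is new or still open speak of the compounds shown alone.

Compound 1: `COC(=O)c1ccc(NCc2cncn2Cc2cccc(C#N)c2)cc1-c1ccccc1` — > 10000 nM
Compound 2: `c1ccc(-c2ccc(Cn3cncc3CNc3ccc(-c4nc5ccccc5o4)c(-c4ccccc4)c3)cc2)cc1` — > 10000 nM

Of the compounds shown here, two have been measured in a toxicity assay on NIH3T3 cells (Mus musculus) for cytotoxicity, read by resazurin assay; a higher number here means that more compound is needed for the effect, a lower number that less compound is needed. Compound 1, `COC(=O)c1ccc(NCc2cncn2Cc2cccc(C#N)c2)cc1-c1ccccc1`, gives > 10000 nM in this assay, which is a limit of the assay and not a number. Compound 2, `c1ccc(-c2ccc(Cn3cncc3CNc3ccc(-c4nc5ccccc5o4)c(-c4ccccc4)c3)cc2)cc1`, gives > 10000 nM in this assay, likewise a limit. Compound 1 thus stands at the limit of > 10000 nM in this assay, at which 2 of the 2 values shown sit; both measured values sit there, so the two measurements show the same thing and nothing more.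

Compound 3, `COC(=O)c1ccc(NCc2cncn2Cc2ccccc2Br)cc1-c1ccccc1`, has not been measured. It differs from compound 1 in one place: 2-bromophenyl in place of 3-cyanophenyl on a saturated chain carbon bound to an aromatic nitrogen. For the measured compounds named here, no step between two measured compounds is available to calibrate this change; what the two measured values show is only that neither compound reached a half-maximal effect within the range of the assay. No shift beyond the usual scatter is expected in this assay. The estimated step is a step that the limit leaves unreadable from compound 1 to compound 3, within the usual scatter. Compound 3 is therefore expected to give 15000 nM in this assay, with a range from 5000 nM to 50000 nM, and most likely to be reported again only as a limit.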

Compound 3, half-maximal effective concentration: 10000 nM
The estimate for compound 3 lay 1.5-fold (0.18 log units) above the measured number; the measured number falls inside the stated range.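

In this assay, replacing 3-cyanophenyl with 2-bromophenyl on a saturated chain carbon bound to an aromatic nitrogen gives a number no higher from compound 1 to compound 3 (the limit leaves the size open). Compound 3 gives 10000 nM, a measured number. The earlier compounds shown here gave only limits, and the number of compound 3 coincides with the figure at which those limits stand. The size of the step cannot be read, so the result shows only that this position tolerates the change without any readable departure from the limit, where most of the values shown still sit: the limit of > 10000 nM in this assay, at which 2 of the 3 values shown sit.

The compounds shown leave open whether the number of compound 3 belongs to the bromine or to its place on the ring, as the group and its place change together in this single step; a 3-bromobenzyl or a 2-cyanobenzyl group at this position would part the two. Also open, from the compounds shown here alone, is what a plain benzyl group or an aminomethyl-bearing benzyl group would give here, and whether any group at this position can bring a value clearly under the figure reached by compound 3.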